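The source may hold more compounds than are shown below. What is called first, only, known or untested is meant among the compounds shown, and "the series" means these compounds.

Compound 1 `COC(=O)N1N=C(c2ccccc2)CC1c1cc(OC)c(OC)c(OC)c1`: 2770 nM
Compound 2 `CCOC(=O)N1N=C(c2ccccc2)CC1c1cc(OC)c(OC)c(OC)c1`: 6720 nM
Compound 3 `COC(=O)N1N=C(c2cccc(OC)c2)CC1c1cc(OC)c(OC)c(OC)c1`: 2780 nM

All three values come from a functional assay on A2780 cells (Homo sapiens) for antiproliferative activity, read by MTT assay, with a stated time of 48 h; a lower number here means a stronger inhibitor of growth, a higher number a weaker inhibitor of growth. Of the three numbers, compound 3 has the second highest, at 2780 nM. It is level with compound 1, as a 1.0-fold higher number from compound 1 to compound 3 (0.00 log units; within the scatter) lies within the scatter. That step is a methoxy in place of hydrogen on an aromatic carbon. Set against compound 3, compound 2 gives a higher number, at 6720 nM.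

The next compound is compound 4 `CCOC(=O)N1N=C(c2cccc(OC)c2)CC1c1cc(OC)c(OC)c(OC)c1`. It keeps everything in compound 3 except for one change: methyl in place of hydrogen on a saturated chain carbon bound to an oxygen next to a carbonyl group. This is a methyl in place of hydrogen on a saturated chain carbon bound to an oxygen next to a carbonyl group, which turns methoxycarbonyl into ethoxycarbonyl.

The same change has been measured once before, without the added methoxy, as a 2.4-fold higher number from compound 1 to compound 2 (0.38 log units; beyond the scatter). That step is modest but beyond the scatter. A single pair is thin evidence, so the size may not carry over in full, but the direction points towards weaker growth inhibition. Accordingly, a 2.2-fold higher number from compound 3 to compound 4 (0.33 log units; beyond the scatter) is expected. For compound 4 the estimated value is 6000 nM, with an expected range from 3300 nM to 11000 nM.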

Compound 4, concentration for 50% growth inhibition: 7300 nM
The estimate for compound 4 lay 1.2-fold (0.09 log units) below the measured number; the measured number falls inside the stated range.
By their numbers in this assay, from the lowest: compounds 1 and 3 (each within the scatter of the next); then compounds 2 and 4 (each within the scatter of the next).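

In this assay, extending methoxycarbonyl to ethoxycarbonyl gives a 2.6-fold higher number from compound 3 to compound 4 (0.42 log units; beyond the scatter), so the loss of growth inhibition first seen on the core of compound 1 returns on a second core, and at much the same size: the same change on two cores in this assay, a 2.4-fold higher number (0.38 log units; beyond the scatter) from compound 1 to compound 2 and a 2.6-fold higher number (0.42 log units; beyond the scatter) from compound 3 to compound 4, 1.1-fold (0.03 log units) apart, within the scatter of two such steps The added methoxy on the aromatic carbon can now also be read with ethoxycarbonyl in place, as a 1.1-fold higher number from compound 2 to compound 4 (0.04 log units; within the scatter), and it again makes no difference that can be told from the scatter: the same change on two cores in this assay, a 1.0-fold higher number (0.00 log units; within the scatter) from compound 1 to compound 3 and a 1.1-fold higher number (0.04 log units; within the scatter) from compound 2 to compound 4, 1.1-fold (0.03 log units) apart, within the scatter of two such steps Across these four compounds, then, the number follows the methoxycarbonyl or ethoxycarbonyl group and stays level with or without the added methoxy, and none of the four goes against this.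

Two groups at one place cannot show whether the trend runs on, so a longer chain such as propoxycarbonyl could weaken growth inhibition further or could leave it level with ethoxycarbonyl. As far as these compounds go, it also remains open how a quite different replacement would behave, such as a carboxylic acid in place of methoxycarbonyl, or an amine in place of the added methoxy on the aromatic carbon.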